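This account rests on a few compounds, and the source may have more. Where it says the series, first, only, none or still open, it means among the compounds named here.

Compound 1 `NS(=O)(=O)c1ccccc1-c1cnc(C(=O)CCCCCCc2ccccc2)o1` — 1500 nM
Compound 2 `NC(=O)c1cccc(-c2cnc(C(=O)CCCCCCc3ccccc3)o2)c1` — 6 nM
Compound 3 `O=C(CCCCCCc1ccccc1)c1ncc(-c2ccc(F)cc2)o1` — 62 nM

In an assay (Rattus norvegicus) for inhibition of Fatty-acid amide hydrolase 1 (Homo sapiens) (on this read-out lower numbers stand for stronger inhibition and higher numbers for weaker inhibition), compound 2 gives the lowest number of the three, with compound 3 as its nearest neighbour and compound 1 far behind it. Compound 4 `N#Cc1ccc(-c2cnc(C(=O)CCCCCCc3ccccc3)o2)cc1` is not yet measured; it differs from compound 2 by 4-cyanophenyl in place of 3-carbamoylphenyl on an aromatic carbon. Among the compounds with values here, the only measured step on the same aromatic carbon is a 10-fold higher number from compound 2 to compound 3 (1.01 log units; beyond the scatter), where a 4-fluorophenyl replaced the 3-carbamoylphenyl and the number rose sharply. The 4-cyanophenyl entering in compound 4 likewise carries no hydrogen-bond donor, though it keeps one hydrogen-bond acceptor, so the account expects a step in the same direction as that from compound 2 to compound 3, probably of a comparable size. The step of a 6.7-fold higher number from compound 2 to compound 4 (0.82 log units; beyond the scatter) is therefore the expectation. Compound 4 is estimated at 40 nM, with a range from 10 nM to 160 nM.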

Compound 4, inhibition constant: 40 nM
Compound 4: the middle estimate sits on the measured number at the digits printed; the range from low to high includes it.
By their numbers in this assay, from the lowest: compound 2; then compounds 4 and 3 (each within the scatter of the next); then compound 1.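

In this assay, a second group without a hydrogen-bond donor also falls short of the 3-carbamoylphenyl, with a 6.7-fold higher number from compound 2 to compound 4 (0.82 log units; beyond the scatter), so the gap seen with compound 3 no longer rests on a single replacement, and the hydrogen-bond acceptor counted on the 4-cyanophenyl does not bring the number back to that of compound 2. The 4-cyanophenyl and the 4-fluorophenyl cannot be told apart here, with a 1.6-fold lower number from compound 3 to compound 4 (0.19 log units; within the scatter), so this change of cyano for fluoro does not register at this position. No measurement offered here accounts for these differences.

The compounds shown leave open whether the advantage of compound 2 lies in the carbamoyl group itself or in where it sits on the phenyl ring. They also leave open how a carboxylic acid or an amine on that ring would compare.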